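The source may report more compounds than this note shows. Statements on the series, on what has been measured and on what is new or still open speak of the compounds shown alone.

The measured compounds are:

compound 1 `CSCc1ccc(Nc2ncc(Cc3c(F)cccc3F)o2)cc1` with > 100000 nM
compound 2 `Clc1cccc(Cl)c1Cc1nnc(Nc2ccc(COCc3cccnc3)cc2)o1` with 81000 nM
compound 3 `Clc1cccc(Cl)c1Cc1nnc(Nc2ccc(COCc3ccncc3)cc2)o1` with 81000 nM

In an ADME assay on MT2 cells (Homo sapiens) for cytotoxicity, read by MTT assay (a higher number here means that more compound is tolerated, a lower number that less compound is tolerated), compound 1 is recorded only as a limit, > 100000 nM, so no number is known for it; it sits at the limit of > 100000 nM in this assay, at which 1 of the 3 values shown sits. Compound 2 gives 81000 nM in this assay, and compound 3 gives 81000 nM. Among the compounds with values here, the one measured step between compounds that differ in a single place is no change at the digits printed from compound 2 to compound 3 (within the scatter), where a pyridin-4-yl takes the place of a pyridin-3-yl on a saturated chain carbon bound to an oxygen on a saturated carbon.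

Compound 4 `Fc1cccc(F)c1Cc1cnc(Nc2ccc(CCOc3ccncc3)cc2)o1` has not yet been measured in this assay. It differs from compound 1 by ((pyridin-4-yl)oxy)methyl in place of methylsulfanyl on a saturated chain carbon bound to an aromatic carbon. The step from compound 2 to compound 3 bears on this change only in part, since it concerns the position of the ring nitrogen in a pyridinyl group joined through an oxygen and shows no change beyond the scatter. Compound 2 and compound 3, which carry such a pyridinyl group, both sit at a number rather than at the limit, whereas compound 1 sits at the limit. Compound 4 is therefore expected to lie near compound 2 and compound 3, with an expected step of an at least 1.1-fold lower number from compound 1 to compound 4 (0.04 log units; that floor lies within the scatter). Compound 4 is estimated at 90000 nM, within 40000 nM to 200000 nM.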

Compound 4, half-maximal cytotoxic concentration: 11000 nM
The estimate for compound 4 lay 8.2-fold (0.91 log units) above the measured number; the measured number lies below the stated range.
By their numbers in this assay, from the lowest: compound 4; then compounds 2 and 3 (each within the scatter of the next). At a limit, above all of these: compound 1.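

In this assay, putting ((pyridin-4-yl)oxy)methyl in place of methylsulfanyl on a saturated chain carbon bound to an aromatic carbon gives an at least 9.0-fold lower number from compound 1 to compound 4 (0.95 log units; beyond the scatter), so this place in the molecule does respond to a change. The earlier pair offered no such sign: it differs only in where the nitrogen sits in the pyridinyl ring, and it gave no change at the digits printed from compound 2 to compound 3 (within the scatter), in another part of the structure and on another core. Compound 1 is recorded only as a limit, > 100000 nM, and the step is a bound rather than an exact size because it starts from that limit: the limit of > 100000 nM in this assay, at which 1 of the 4 values shown sits.

As far as these compounds go, what remains open is which part of the entering group goes with the lower number, since the pyridin-4-yl ring, the oxygen and the longer chain all enter together in compound 4. A phenoxy group or a plain methoxy group at this place would separate these parts, and whether the position of the ring nitrogen matters here, as it did not in the earlier pair, also stays unanswered.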